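This account rests on a few compounds, and the source may have more. Where it says the series, first, only, none or still open, it means among the compounds named here.

Measured compounds in a functional assay on MIA PaCa-2 cells (Homo sapiens) for antiproliferative activity, read by MTT assay, with a stated time of 72 h; a higher number here means that more compound is needed for the effect, a lower number that less compound is needed:

Compound 1, `Cc1nn(Cc2ccc(C(N)=O)cc2)c(C)c1NC(=O)c1ccc(COc2ccccc2)cc1`: in this assay compound 1 reaches only the limit > 100000 nM, a boundary of the assay rather than a number.
Compound 2, `Cc1nn(Cc2cccc(C(N)=O)c2)c(C)c1NC(=O)c1ccc(COc2ccccc2)cc1`: compound 2 gives 9200 nM.
Compound 3, `Cc1nn(Cc2ccccc2C(N)=O)c(C)c1NC(=O)c1ccc(COc2ccccc2)cc1`: compound 3 gives 42000 nM.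

Of the two numbers given, compound 2 gives the lowest, with compound 3 nearest: a 4.6-fold higher number from compound 2 to compound 3 (0.66 log units; beyond the scatter). The other measured steps move the carbamoyl group around its ring, an at least 10-fold lower number from compound 1 to compound 2 (1.03 log units; beyond the scatter) and an at least 2.3-fold lower number from compound 1 to compound 3 (0.37 log units; beyond the scatter); the position on that ring clearly matters.

Compound 4, `CCNC(=O)c1cccc(Cn2nc(C)c(NC(=O)c3ccc(COc4ccccc4)cc3)c2C)c1`, keeps the 3-carbamoylphenyl arrangement of compound 2 and differs only in that (ethyl in place of hydrogen on an amide-type nitrogen). Among the compounds with values here, none of the measured steps touches this amide nitrogen, so no measured step shows how such a change acts here. With the carbamoyl kept in its favoured place, a step that stays within the scatter is expected, with no preferred direction. For compound 4 the expected value in this assay is 10000 nM, within 3000 nM to 35000 nM, meaning an expected step of a 1.1-fold higher number from compound 2 to compound 4 (0.04 log units; within the scatter).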

Compound 4, half-maximal effective concentration: 11000 nM
Compound 4: middle estimate off by 1.1-fold (0.04 log units), on the low side; low and high end bracket the measured number.
By their numbers in this assay, from the lowest: compounds 2 and 4 (each within the scatter of the next); then compound 3. At a limit, above all of these: compound 1.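

Earlier compounds showed only that the place of the carbamoyl group on its ring matters; in this assay the amide hydrogen can also give way to ethyl without leaving the scatter, with a 1.2-fold higher number from compound 2 to compound 4 (0.08 log units; within the scatter). The 3-(ethylcarbamoyl)phenyl group also keeps a clear lead over the 2-carbamoylphenyl group, with a 3.8-fold lower number from compound 3 to compound 4 (0.58 log units; beyond the scatter). Against compound 1, whose value is a limit of the assay and not a number, the step is an at least 9.0-fold lower number from compound 1 to compound 4 (0.95 log units; beyond the scatter).

Nothing measured here explains why the ethyl group is accepted on this nitrogen. From the compounds shown here alone, it remains open whether a longer chain such as butyl, a chain ending in an amine, or a carboxylic acid in place of the whole amide would keep the number in this range or move it.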